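Hydroxymethyl addition on two different cores

The source may report more compounds than this note shows. Statements on the series, on what has been measured and on what is new or still open speak of the compounds shown alone.

Measured compounds:
compound 1 `COc1ccc(O)c(CSc2ccccc2)c1` – 590 nM
compound 2 `COc1ccc(O)c(CSc2ccccc2CO)c1` – 8700 nM
compound 3 `Oc1cc2ccoc2cc1CNc1ccccc1` – 11000 nM

In a functional assay for inhibition, with Homo sapiens as the target (a higher number here means a weaker inhibitor, a lower number a stronger inhibitor), compound 1 gives 590 nM. The change to compound 2 hydroxymethyl in place of hydrogen on an aromatic carbon produced a 15-fold higher number from compound 1 to compound 2 (1.17 log units; beyond the scatter). Compound 3 stands apart from compound 1 by a different core; the difference between the two cores is not broken down here. Compound 4 `OCc1ccccc1NCc1cc2occc2cc1O` carries the same change on the core of compound 3, (hydroxymethyl in place of hydrogen on an aromatic carbon).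

Two occurrences of this change are present in the series, one measured. For the measured compounds named here, the single measured step is large and beyond the scatter, so the expectation for compound 4 in this assay rests on it alone. Compound 4 is expected to be a weaker inhibitor than compound 3 because a 15-fold higher number from compound 1 to compound 2 (1.17 log units; beyond the scatter) points that way; the estimated step is a 4.5-fold higher number from compound 3 to compound 4 (0.66 log units; beyond the scatter). Compound 4 is estimated at 50000 nM, with an expected range from 12000 nM to 200000 nM.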

Compound 4, half-maximal inhibitory concentration: 42000 nM
Estimate against measurement, compound 4: 1.2-fold (0.08 log units) above, and the stated range covers the measured number.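

In this assay, hydroxymethyl in place of hydrogen on an aromatic carbon again gives a weaker inhibitor on the second core, with a 3.8-fold higher number from compound 3 to compound 4 (0.58 log units; beyond the scatter). The direction of the change carries over between the two cores, but its size does not: the same change on two cores in this assay, a 15-fold higher number (1.17 log units; beyond the scatter) from compound 1 to compound 2 and a 3.8-fold higher number (0.58 log units; beyond the scatter) from compound 3 to compound 4, 3.9-fold (0.59 log units) apart, beyond the scatter of two such steps. Two cores cannot show how the size of this step depends on the core, or which difference between the cores goes with the gap, so a step measured on one core gives only the direction for the other.

On these data alone, whether a methyl, an aminomethyl or a carboxylic acid in the same place would give a similar step remains open. Also open, as far as these compounds go, is whether the direction holds on any further core.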